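Thiophen-3-yl for furan-3-yl: compound 3 to compound 4

This account rests on a few compounds, and the source may have more. Where it says the series, first, only, none or still open, it means among the compounds named here.

Of the compounds shown here, three have been measured in an assay on CHO cells for displacement of a labelled ligand from adenosine receptor A1 (Homo sapiens), with a stated time of 60 min, tested at 10 uM; a lower number here means less inhibition, a higher number more inhibition at the concentration tested (going by the name of the read-out). Compound 1 `CCOC(=O)C1=C(C)NC(=O)N(C(C)=O)C1c1ccco1` gives 19%. Compound 2 `CCOC(=O)C1=C(C)NC(=S)NC1c1ccoc1` gives 18%. Compound 3 `CC1=C(C(=O)OC(C)C)C(c2ccoc2)NC(=S)N1` gives 18%; it stands level with compound 2 and, together with it, at the lowest of the three numbers, while the gap to compound 1 lies within the scatter. For the measured compounds named here, the one step recorded within the set, no change at the digits printed from compound 2 to compound 3 (within the scatter), left the read-out where it was.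

Compound 4 `CC1=C(C(=O)OC(C)C)C(c2ccsc2)NC(=S)N1` is the next member and differs from compound 3 in one place: thiophen-3-yl in place of furan-3-yl on a saturated ring carbon. Going by the values given here, no measured step in this set exchanges one five-membered aromatic ring for another, so the only guide is the flatness of the series so far: the ester change moved nothing, and all three numbers sit within the scatter of one another. The expectation for compound 4 in this assay is therefore no step beyond the scatter, a number 2 percentage points higher from compound 3 to compound 4 (within the scatter). Compound 4 is estimated at 20%, with a range from 6% to 34%.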

Compound 4, a percentage reported as inhibition, at one concentration (the size of the read-out at that concentration, not a potency): 16%
The estimate for compound 4 lay 4 percentage points above the measured number; low and high end bracket the measured number.
By their numbers in this assay, from the lowest: compounds 4, 2, 3 and 1 (each within the scatter of the next).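

In this assay the exchange on this saturated ring carbon gives a number 2 percentage points lower from compound 3 to compound 4 (within the scatter) with thiophen-3-yl in place of furan-3-yl, so the ring's oxygen can be swapped for sulfur at this position without a step beyond the scatter. The read-out now stays flat at a second place on the shared core, after no change at the digits printed from compound 2 to compound 3 (within the scatter) at the ester, although so small a read-out at a single concentration says little about either group. Nothing measured here bears on why this exchange leaves the number within the scatter.

On these data alone, what a phenyl ring, or a furan-3-yl or thiophen-3-yl ring carrying an amine or a carboxylic acid, would do at this carbon remains open. Also open, as far as these compounds go, is whether any change at this position can move the number in this assay beyond the scatter.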